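Swapping a Ring Halogen: Predicting Compound 4

A few compounds are considered here, and "the series" means these few. Any claim that something is new, unique, unknown or untested is made for them only; others in the source may bear on it.

In a functional assay on the whole organism (strain Swiss) with Mus musculus as the target, in the maximal electroshock model, with a stated time of 0.5 h, at a dose of 100 mg/kg by the intraperitoneal route (a higher number here means a stronger effect of the compound at the dose given, a lower number a weaker effect), compound 3 `CC(C(=O)N1CCN(c2ccc(Cl)cc2)CC1)N1C(=O)CCC1=O` gives 25%. That number is level with compound 1 `CC(C(=O)N1CCN(c2ccccc2C(F)(F)F)CC1)N1C(=O)CCC1=O`, which gives 25%, and together they are the lowest of the three; compound 2 `CC(C(=O)N1CCN(c2cccc(Cl)c2)CC1)N1C(=O)CCC1=O` gives 75%. Compound 4 `CC(C(=O)N1CCN(c2ccccc2F)CC1)N1C(=O)CCC1=O` differs from compound 3 in one place: 2-fluorophenyl in place of 4-chlorophenyl on an amine nitrogen in a ring. Within the data shown here, the only measured single-point step is a number 50 percentage points lower from compound 2 to compound 3 (beyond the scatter), a large fall, showing that where a chlorine sits on this phenyl ring matters; no measured step shows what a fluorine does. Compound 1 carries a different group on this phenyl ring and sits level with compound 3. Compound 4 is therefore expected to change little, an expected step of a number 5 percentage points higher from compound 3 to compound 4 (within the scatter), giving an estimate of 30% with a range from 10% to 60%.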

Compound 4, a percentage reported as activity, at one dose (the size of the read-out at that dose, not a potency): 0%
For compound 4 the middle estimate is 30 percentage points above the measured one; measured number below the stated range.
By their numbers in this assay, from the lowest: compound 4; then compounds 1 and 3 (each within the scatter of the next); then compound 2.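

In this assay the 2-fluorophenyl group takes the read-out lower than any earlier group on this ring, with compound 4 the lowest of the four: the change from 4-chlorophenyl gives (a number 25 percentage points lower from compound 3 to compound 4 (beyond the scatter)) and the change from 3-chlorophenyl gives (a number 75 percentage points lower from compound 2 to compound 4 (beyond the scatter)). Fluoro in place of trifluoromethyl on an aromatic carbon also lowers it (a number 25 percentage points lower from compound 1 to compound 4 (beyond the scatter)), so neither group at this place matches the 3-chlorophenyl result. Nothing measured here gives a reason for these falls.

Still open, going by these compounds, is whether 3-fluorophenyl would hold the read-out of compound 2, which would separate the choice of halogen from its place on the ring. A methoxy group or a nitrile on this phenyl ring is also untested ground in these compounds.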